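Enone series: thiophene for bromophenyl, expected inhibition

The source may hold more compounds than are shown below. What is called first, only, known or untested is meant among the compounds shown, and "the series" means these compounds.

Compound 1 `Cc1nc(NC(=O)c2ccccc2)sc1C(=O)/C=C/c1cccc(Br)c1` is the reference point for the present step. Going by the values given here, in an assay for inhibition of Polyunsaturated fatty acid 5-lipoxygenase (Homo sapiens), read by spectrophotometry, tested at 10 uM, in the presence of a further agent that is not named here (a higher number here means more inhibition at the concentration tested (going by the name of the read-out), a lower number less inhibition), compound 1 gives 42.5%, the lowest of the three numbers so far. Compound 2 `COc1ccc(C(=O)Nc2nc(C)c(C(=O)/C=C/c3ccc(F)cc3)s2)cc1` gives 88.2% in this assay, and compound 3 `COc1ccc(/C=C/C(=O)c2sc(NC(=O)c3ccccc3)nc2C)cc1OC` gives 70.2%. The number for compound 1 sits beyond the scatter below both of these: the nearest is compound 3, the furthest compound 2. Among the compounds with values here, compounds 2 and 3 differ from compound 1 in more than one place, so no single step between measured compounds has been worked out; their values show only that the shared core can reach well above what compound 1 gives.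

Compound 4 `Cc1nc(NC(=O)c2ccccc2)sc1C(=O)/C=C/c1cccs1` is not yet measured. It differs from compound 1 by one change: thiophen-2-yl in place of 3-bromophenyl on a double-bonded chain carbon bound to a double-bonded chain carbon. On these data alone, nothing measured bears directly on this exchange, so the direction remains open. The expected step of a number 7.5 percentage points higher from compound 1 to compound 4 (within the scatter) is a modest rise, within or near the scatter, given that compound 1 stands at 42.5% with room above it. For compound 4 the estimate in this assay is 50%, with a range from 25% to 75%.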

Compound 4, a percentage reported as inhibition, at one concentration (the size of the read-out at that concentration, not a potency): 71.9%
Compound 4: the middle estimate sits 21.9 percentage points below what was measured; measured number inside the range.
By their numbers in this assay, from the lowest: compound 1; then compounds 3 and 4 (each within the scatter of the next); then compound 2.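

Working from the same core, the group on a double-bonded chain carbon bound to a double-bonded chain carbon is now shown to matter on its own: in this assay, thiophen-2-yl in place of 3-bromophenyl gives a number 29.4 percentage points higher from compound 1 to compound 4 (beyond the scatter). The earlier comparisons shown here all involved changes in more than one place, whereas this single exchange, with the rest of the structure unchanged, ties a change beyond the scatter to this position. The step does not separate the loss of the bromine from the change of ring, as both happen in the same exchange, and no measurement at hand accounts for the rise.

Still open, on these data alone, is whether the gain follows the thiophen-2-yl ring itself or simply the absence of the bromine, a question that unsubstituted phenyl or furan-2-yl at this place would bear on directly. Also open, as far as these compounds go, is whether the same exchange gives a similar step when the benzoyl group on the amide carries a methoxy group, since the series shows this exchange on one background only.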